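Nitro for Methoxy on the Sulfonyl Ring

The source may hold more compounds than are shown below. What is called first, only, known or untested is meant among the compounds shown, and "the series" means these compounds.

Measured compounds:
Compound 1 `COc1ccc(Cc2nnc(NC(=O)/C(C#N)=C/c3ccccc3OS(=O)(=O)c3ccc(OC)cc3)s2)cc1` gives 78% in a functional assay on RS4-11 cells (Homo sapiens) for inhibition, read by CCK-8 assay, with a stated time of 48 h, tested at 20 uM; a higher number here means more inhibition of growth at the concentration tested, a lower number less inhibition of growth.
Compound 2 `COc1ccc(Cc2nnc(NC(=O)/C(C#N)=C/c3ccccc3OS(=O)(=O)c3ccc([N+](=O)[O-])cc3)s2)cc1` gives 70%.
Compound 3 `COc1ccc(S(=O)(=O)Oc2ccccc2/C=C(\C#N)C(=O)Nc2nnc(Cc3ccccc3)s2)cc1` gives 78%.

Compound 1 and compound 3 share a core that differs in one place, (hydrogen in place of methoxy on an aromatic carbon), and in this assay the result is no change at the digits printed from compound 1 to compound 3 (within the scatter). The two values therefore sit together as the highest of the three, with no order between them.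

Compound 2 differs from compound 1 only by nitro in place of methoxy on an aromatic carbon, and that change gave a number 8 percentage points lower from compound 1 to compound 2 (within the scatter). The compound still to be tested, compound 4 `N#C/C(=C\c1ccccc1OS(=O)(=O)c1ccc([N+](=O)[O-])cc1)C(=O)Nc1nnc(Cc2ccccc2)s1`, carries exactly the same change relative to compound 3, (nitro in place of methoxy on an aromatic carbon). The place of the change reads the same in both pairs, on an aromatic carbon of a six-membered aromatic ring of carbon only, para to a large group, so this is the same change made on the other core.

Because compound 1 and compound 3 gave no change at the digits printed from compound 1 to compound 3 (within the scatter), the two cores look interchangeable in this test, and because the change in compound 2 gave a number 8 percentage points lower from compound 1 to compound 2 (within the scatter), compound 4 is expected to move by a similar small amount, a number 7 percentage points lower from compound 3 to compound 4 (within the scatter). The estimate for compound 4 in this assay is 71%, expected to lie between 58% and 84%.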

Compound 4, percent growth inhibition at one concentration: 57%
Estimate against measurement, compound 4: 14 percentage points above; measured number outside the range, below it.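

On the core of compound 3, going from (4-methoxyphenyl)sulfonyl to (4-nitrophenyl)sulfonyl in this assay gave a number 21 percentage points lower from compound 3 to compound 4 (beyond the scatter), and set beside the same change on the core of compound 1, this step cannot be told apart from the earlier one: the same change on two cores in this assay, a number 8 percentage points lower (within the scatter) from compound 1 to compound 2 and a number 21 percentage points lower (beyond the scatter) from compound 3 to compound 4, 13 percentage points apart, within the scatter of two such steps. With nitro in place on the sulfonyl side, putting hydrogen in place of methoxy on the other aromatic ring gave a number 13 percentage points lower from compound 2 to compound 4 (beyond the scatter), and this step too cannot be told apart from its counterpart with methoxy on the sulfonyl side: the same change on two cores in this assay, no change at the digits printed (within the scatter) from compound 1 to compound 3 and a number 13 percentage points lower (beyond the scatter) from compound 2 to compound 4, 13 percentage points apart, within the scatter of two such steps. Within the data shown here, the change therefore carried from one core to the other without a measurable difference between the two steps, yet only the step on the core of compound 3 lies beyond the scatter, and one pair on each core shows neither that the step has the same size on both nor that it differs.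

From the compounds shown here alone, whether an amine or a carboxylic acid on that same aromatic carbon would behave like methoxy or like nitro stays open, as does the effect of a longer chain in place of the methoxy on the other ring. Growth inhibition at a single concentration also leaves open how these compounds would compare across a range of concentrations.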